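This account rests on a few compounds, and the source may have more. Where it says the series, first, only, none or still open, it means among the compounds named here.

Compound 1 `COc1cc2ncnc(Nc3ccc(F)c(Cl)c3)c2cc1OCCn1ccnc1[N+](=O)[O-]` gives 10000 nM in a functional assay on HT-29 cells (Homo sapiens) for cytotoxicity, read by sulforhodamine B assay, with a stated time of 72 h; a lower number here means a stronger inhibitor, a higher number a weaker inhibitor. Compound 2 `COc1cc2ncnc(Nc3ccc(F)c(Cl)c3)c2cc1OCCCCCn1ccnc1[N+](=O)[O-]` gives 5590 nM in this assay. Compound 3 `C#Cc1cccc(Nc2ncnc3cc(OC)c(OCCCCCCn4ccnc4[N+](=O)[O-])cc23)c1` gives 3460 nM in this assay.

Compound 2 stands second highest of the three numbers. Its nearest neighbour is compound 3, whose number sits within the scatter of that of compound 2, and compound 1 lies at a similar small distance on the other side, also within the scatter. For the measured compounds named here, no compound here can be called stronger or weaker than another.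

Compound 4 `COc1cc2ncnc(Nc3ccc(F)c(Cl)c3)c2cc1OCCn1c([N+](=O)[O-])cnc1C` differs from compound 2 by 2-methyl-5-nitro-1H-imidazol-1-yl in place of 3-(2-nitro-1H-imidazol-1-yl)propyl on a saturated chain carbon, two bonds along the chain from an oxygen on an aromatic ring. Going by the values given here, the one measured step that bears on this change is a 1.8-fold lower number from compound 1 to compound 2 (0.25 log units; within the scatter), which covers the part of the change that removes the propyl spacer and leaves only a two-carbon link; it stayed within the scatter. Among the compounds with values here, no measured pair speaks to moving the nitro group and adding the methyl on the imidazole ring, so that part carries no guidance. On that footing a step in this assay from compound 2 to compound 4 is expected to stay within the scatter, with compound 4 estimated near the number of compound 1 because of 10000 nM.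

Compound 4 is therefore expected at 8000 nM, within a range of 3000 nM to 20000 nM. That estimate for compound 4 means an expected step of a 1.4-fold higher number from compound 2 to compound 4 (0.16 log units; within the scatter).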

Compound 4, half-maximal inhibitory concentration: > 50000 nM
Compound 4: no number, only a limit; the forecaster's own chance of this, stated with the estimate: 25%; middle value at least 6.2-fold (0.79 log units) away from the limit.
By their numbers in this assay, from the lowest: compounds 3, 2 and 1 (each within the scatter of the next, the first and the last beyond it). At a limit, above all of these: compound 4.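

In this assay compound 4 stands at a limit of the assay and not at a number: the limit of > 50000 nM in this assay, at which 1 of the 4 values shown sits. With the two-carbon link kept, the exchange of 2-nitro-1H-imidazol-1-yl for 2-methyl-5-nitro-1H-imidazol-1-yl gives an at least 5.0-fold higher number from compound 1 to compound 4 (0.69 log units; beyond the scatter), and the exchange that also shortens the chain gives an at least 8.9-fold higher number from compound 2 to compound 4 (0.95 log units; beyond the scatter). Both steps lie beyond the scatter, whereas the change in chain alone, a 1.8-fold lower number from compound 1 to compound 2 (0.25 log units; within the scatter), stayed within it, so at this position on the saturated chain the make-up of the nitroimidazole shows a clear effect on the number that chain length did not show.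

The compounds shown leave open whether the methyl group, the different placing of the nitro group or the two together carry this step, since compound 4 changes both at once. They also leave open how 2-methyl-5-nitro-1H-imidazol-1-yl would read on a longer chain, such as the pentyl-length link of compound 2, and whether a small group such as an amine or a carboxylic acid on the imidazole would give a comparable step.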